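Working notes: furan-2-yl for 3-methoxyphenyl

This account rests on a few compounds, and the source may have more. Where it says the series, first, only, none or still open, it means among the compounds named here.

Values in a functional assay on MCF7 cells (Homo sapiens) for inhibition, read by CCK-8 assay, with a stated time of 48 h (on this read-out lower numbers stand for stronger inhibition of growth and higher numbers for weaker inhibition of growth), follow
- compound 1 `CN1CCN(c2ccc(Nc3ncc(Cl)c(Nc4ccccc4)n3)nc2)CC1` gives 51800 nM
- compound 2 `CN1CCN(c2ccc(Nc3ncc(Cl)c(NCc4ccccc4)n3)nc2)CC1` gives 17300 nM
- compound 3 `COc1cccc(CNc2nc(Nc3ccc(N4CCN(C)CC4)cn3)ncc2Cl)c1` gives 19500 nM

Compound 3 belongs to the lower pair of the three numbers: (a 1.1-fold higher number from compound 2 to compound 3 (0.05 log units; within the scatter)) stays within the scatter, and (a 2.7-fold lower number from compound 1 to compound 3 (0.42 log units; beyond the scatter)) goes beyond it. Next is compound 4 `CN1CCN(c2ccc(Nc3ncc(Cl)c(NCc4ccco4)n3)nc2)CC1` with furan-2-yl in place of 3-methoxyphenyl on a saturated chain carbon bound to a nitrogen on an aromatic ring. The modest step (a 3.0-fold lower number from compound 1 to compound 2 (0.48 log units; beyond the scatter)) came with benzyl in place of phenyl, a change compound 4 does not reverse, since it keeps the saturated chain carbon. Adding methoxy to the benzyl ring gave only (a 1.1-fold higher number from compound 2 to compound 3 (0.05 log units; within the scatter)). For the measured compounds named here, no furan compound has been measured. No step beyond the scatter is therefore expected in this assay for this change. An estimated 1.0-fold higher number from compound 3 to compound 4 (0.01 log units; within the scatter) is expected here. Compound 4 is estimated at 20000 nM (expected range 9000 nM to 42000 nM).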

Compound 4, concentration for 50% growth inhibition: 21300 nM
Compound 4: the middle estimate sits 1.1-fold (0.03 log units) below what was measured; the measured number falls inside the stated range.
By their numbers in this assay, from the lowest: compounds 2, 3 and 4 (each within the scatter of the next); then compound 1.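

In this assay, furan-2-yl on the saturated chain carbon bound to a nitrogen on an aromatic ring is not distinguished from the benzene-ring groups: a 1.1-fold higher number from compound 3 to compound 4 (0.04 log units; within the scatter) and a 1.2-fold higher number from compound 2 to compound 4 (0.09 log units; within the scatter) both stay within the scatter, even with a five-membered aromatic ring entering. The step from the directly attached phenyl remains beyond the scatter, with a 2.4-fold lower number from compound 1 to compound 4 (0.39 log units; beyond the scatter). No measured evidence bears on this result. As far as these compounds go, whether a pyridine ring, an amine or a longer chain at this place would move the number beyond the scatter remains open.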